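The source may report more compounds than this note shows. Statements on the series, on what has been measured and on what is new or still open speak of the compounds shown alone.

Working notes on the series. Compound 1 `COc1ccc(-c2cc(=O)c3c(OC)cc(OC)cc3n2C)cc1` carries a methyl on the ring nitrogen of the shared core; in a functional assay on HepG2 cells (Homo sapiens) for antiproliferative activity, with a stated time of 72 h (on this read-out higher numbers stand for an effect only at larger amounts of compound and lower numbers for an effect already at smaller amounts), compound 1 has "not determined" (no result reported), so it gives no anchor here. Compound 2 `COc1ccc(-c2cc(=O)c3c(OC)cc(OC)cc3n2S(=O)(=O)c2ccc(C)c([N+](=O)[O-])c2)cc1` carries a sulfonyl on that nitrogen. In this assay compound 2 reaches only a limit of the assay, > 51700 nM, and not a number. Among the measured compounds shown here, compound 2 therefore stands at the limit of > 51700 nM in this assay, at which 1 of the 2 values shown sits, the only measured point so far, with no step between measured compounds to draw on.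

Compound 3 `COc1ccc(-c2cc(=O)c3c(OC)cc(OC)cc3n2S(=O)(=O)c2ccc(C#N)cc2)cc1` is the next member. The change from compound 2 is 4-cyanophenyl in place of 4-methyl-3-nitrophenyl on a sulfonyl sulfur; that is, 4-cyanophenyl in place of 4-methyl-3-nitrophenyl on a sulfonyl sulfur. For the measured compounds named here, with compound 2 sitting at the limit of > 51700 nM in this assay, at which 1 of the 2 values shown sits, no measured step tells the size or direction of such a swap, so the working expectation is no shift beyond the usual scatter, a step that the limit leaves unreadable from compound 2 to compound 3. Compound 3 is estimated at 60000 nM, in the range 15000 nM to 200000 nM, most likely returned as a limit again.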

Compound 3, half-maximal effective concentration: > 17200 nM
Compound 3 was reported as a limit; the forecaster's own chance of this, stated with the estimate: 75%; the middle value does not contradict the limit.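

Compound 3 gives > 17200 nM in this assay, a limit and not a number. Among the compounds shown here, compound 2 also sits at a limit, so no step from compound 2 to compound 3 can be read. The compounds shown leave open whether either sulfonyl group gives a measurable effect, and where compound 1 stands.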